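The source may hold more compounds than are shown below. What is called first, only, known or untested is meant among the compounds shown, and "the series" means these compounds.

The shared core is carried by compound 1 `CS(=O)(=O)Nc1ccc2c(c1)S(=O)(=O)N=C(C1=C(O)[C@H]3CCC[C@H]3N(Cc3ccc(F)c(F)c3)C1=O)N2` and by compound 2 `CS(=O)(=O)Nc1ccc2c(c1)S(=O)(=O)N=C(C1=C(O)[C@H]3CCC[C@H]3N(Cc3cccc(C(F)(F)F)c3)C1=O)N2`. In an in vitro ADME assay on microsomes from liver (Homo sapiens) for metabolic stability (on this read-out higher numbers stand for a longer-lived compound and lower numbers for a shorter-lived compound), compound 1 gives > 1 h, which is a limit of the assay and not a number. In this assay compound 2 gives > 1 h, again a limit and not a number. The step that the two limits leave unreadable from compound 1 to compound 2 is thus hidden, and the limit of > 1 h in this assay, at which 2 of the 2 values shown sit, is all the two values show: compound 2 stands at the limit, with no order readable between compound 1 and compound 2.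

Compound 3 `CS(=O)(=O)Nc1ccc2c(c1)S(=O)(=O)N=C(C1=C(O)[C@H]3CCC[C@H]3N(CC3CC3)C1=O)N2` is the next member. Its change from compound 2 is cyclopropyl in place of 3-(trifluoromethyl)phenyl on a saturated chain carbon bound to an amide-type nitrogen in a ring. Among the compounds with values here, the one measured step, a step that the two limits leave unreadable from compound 1 to compound 2, concerns a different substituent on the same saturated chain carbon and its size is unreadable, so no measured step shows how a cyclopropyl in this place behaves. Compound 3 is therefore expected to stay near that limit, with an estimated step that the limit leaves unreadable from compound 2 to compound 3. For compound 3 the estimate is 1.2 h, in a range from 0.4 h to 3 h, with a real chance that this assay again reports only the limit.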

Compound 3, half-life: > 1 h
Compound 3 was reported as a limit; the forecaster's own chance of this, stated with the estimate: 55%; the middle value does not contradict the limit.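

In this assay compound 3 gives > 1 h, a limit and not a number. Within the data shown here, no step among compound 1, compound 2 and compound 3 can be read, and all three share one ceiling: the limit of > 1 h in this assay, at which 3 of the 3 values shown sit. The compounds shown leave open how long each one actually lasts and whether the three substituents differ at all in this read-out.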